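Removing the Acetyl from the Sugar of Compound 1

The source may report more compounds than this note shows. Statements on the series, on what has been measured and on what is new or still open speak of the compounds shown alone.

Compound 1 `C=C[C@@](C)(CC[C@H]1C(C)=CC[C@H]2C(C)(C)CCC[C@]12C)O[C@@H]1O[C@@H](C)[C@@H](OC(C)=O)[C@H](O)[C@H]1O` carries an acetylated sugar on a terpenoid core. In a functional assay on SK-OV-3 cells (Homo sapiens) for cytotoxicity, read by sulforhodamine B assay (a lower number here means that less compound is needed, a higher number that more compound is needed for the effect), compound 1 gives 3.4 ug/mL, the lowest of the two numbers available. Compound 3 `C=C[C@@](C)(CC[C@H]1C(C)=CC[C@H]2C(C)(C)CCC[C@]12C)O[C@@H]1O[C@H](C)[C@H](O)[C@H](OC(C)=O)[C@H]1O`, with the acetyl on a different position of the sugar, gives 3.8 ug/mL in this assay, a gap within the usual scatter, so the two cannot be ranked. Compound 2 `C=C[C@](C)(O)CC[C@H]1C(=C)[C@H](O)C[C@H]2C(C)(C)CCC[C@]12C`, which lacks the sugar altogether, reaches only the limit of > 5 ug/mL in this assay. That is the limit of > 5 ug/mL in this assay, at which 1 of the 3 values shown sits.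

Compound 4 `C=C[C@@](C)(CC[C@H]1C(C)=CC[C@H]2C(C)(C)CCC[C@]12C)O[C@@H]1O[C@@H](C)[C@@H](O)[C@H](O)[C@H]1O` differs from compound 1 by hydrogen in place of acetyl on an oxygen on a saturated carbon, which cut one bond further out reads acetoxy to hydroxy. For the measured compounds named here, no pair of measured compounds shows this change, so the size of the step can only be guessed. Since the values of compound 1 and compound 3 sit close together despite the acetyl moving, the acetyl itself appears not to be decisive, and the expected step of a 1.3-fold higher number from compound 1 to compound 4 (0.12 log units; within the scatter) is estimated to be small, toward a slightly higher number at most. Compound 4 is therefore expected to give 4.5 ug/mL in this assay, within a range of 2.5 ug/mL to 8 ug/mL.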

Compound 4, concentration for half-maximal effect: 5.7 ug/mL
For compound 4 the middle estimate is 1.3-fold (0.10 log units) below the measured one, and the stated range covers the measured number.
By their numbers in this assay, from the lowest: compounds 1, 3 and 4 (each within the scatter of the next).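

In this assay, for the compounds shown here, replacing acetoxy with hydroxy gives a 1.7-fold higher number from compound 1 to compound 4 (0.22 log units; within the scatter), the first reading of this change on this oxygen. The acetyl at this place can therefore be removed without a shift that stands clear of the scatter. Each sugar-bearing compound shown earlier carried an acetyl somewhere on the sugar, whereas compound 4 shows that a measured number remains without one.

Compound 2 stays a limit and not a number, and it gives no step to set beside this one: the limit of > 5 ug/mL in this assay, at which 1 of the 4 values shown sits.

As far as these compounds go, whether a longer acyl chain, a benzoyl group or a methyl ether on this same oxygen would move the number beyond the scatter stays open, as does whether removing the acetyl would behave the same way on the sugar of compound 3.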